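Benzyloxy replacements for the prenyloxy chain of compound 1

This account rests on a few compounds, and the source may have more. Where it says the series, first, only, none or still open, it means among the compounds named here.

Compound 1 `COc1cc(OC)c(-c2coc3cc(OCC=C(C)C)ccc3c2=O)cc1OC` carries the lowest number of the three measured compounds: in a functional assay on HCT-116 cells (Homo sapiens) for antiproliferative activity, read by MTT assay, with a stated time of 24 h (on this read-out lower numbers stand for stronger inhibition and higher numbers for weaker inhibition), compound 1 gives 680 nM. Compound 2 `COc1cc(OC)c(-c2coc3cc(OCc4ccccc4F)ccc3c2=O)cc1OC` gives 2900 nM, and compound 3 `COc1cc(OC)c(-c2coc3cc(OCc4ccc(Br)cc4)ccc3c2=O)cc1OC` gives 1980 nM. Compound 4 `COc1cc(OC)c(-c2coc3cc(OCc4ccc(Cl)cc4)ccc3c2=O)cc1OC` differs from compound 1 in the same place as those two: 4-chlorophenyl in place of 2-methylprop-1-en-1-yl on a saturated chain carbon bound to an oxygen on an aromatic ring. Both measured steps that bear on this change move upward, a 4.3-fold higher number from compound 1 to compound 2 (0.63 log units; beyond the scatter) and a 2.9-fold higher number from compound 1 to compound 3 (0.46 log units; beyond the scatter). Between the two aryl compounds the gap is small, a 1.5-fold lower number from compound 2 to compound 3 (0.17 log units; within the scatter). For compound 4 an upward step beyond the scatter, close to that of compound 3, is therefore expected, roughly a 2.8-fold higher number from compound 1 to compound 4 (0.45 log units; beyond the scatter). Compound 4 is estimated at 1900 nM, within a range from 900 nM to 4000 nM.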

Compound 4, half-maximal inhibitory concentration: 4450 nM
Compound 4: middle estimate off by 2.3-fold (0.37 log units), on the low side; measured number outside the range, above it.
By their numbers in this assay, from the lowest: compound 1; then compounds 3, 2 and 4 (each within the scatter of the next, the first and the last beyond it).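

All three aryl replacements now stand above compound 1, and the 4-chlorophenyl group does so too (a 6.5-fold higher number from compound 1 to compound 4 (0.82 log units; beyond the scatter)). Exchanging the halogen is not neutral here: chloro in place of bromo on an aromatic carbon gives a step beyond the scatter (a 2.2-fold higher number from compound 3 to compound 4 (0.35 log units; beyond the scatter)), while the 4-chlorophenyl and 2-fluorophenyl groups remain unseparated (a 1.5-fold higher number from compound 2 to compound 4 (0.19 log units; within the scatter)). No available measurement explains these differences.

Open, from the compounds shown here alone, is whether unsubstituted benzyl or a longer alkenyl chain such as geranyl on the same oxygen would come back to the level of compound 1.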